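The compounds below may be only part of what the source reports. "The series", "measured", "known", "first", "only" and "open" are said of these compounds alone.

Working notes on the series. In a functional assay on U-251 cells (Homo sapiens) for inhibition, read by MTT assay, with a stated time of 48 h (a higher number here means a weaker inhibitor, a lower number a stronger inhibitor), compound 1 (`C#CCN(C)CCCOc1cc(NCc2ccc(/C=C/C(=O)NO)cc2)ccc1Cl`) gives 3240 nM. Compound 2 (`C#CCN(C)CCCOc1cc(NC(=O)CCCCCCCCC(=O)NO)ccc1Cl`) gives 33200 nM, the higher of the two numbers and so the weaker inhibitor of the pair, with a gap beyond the scatter. Compound 3 (`C#CCN(C)CCCOc1cc(NC(=O)CCCCCCCC(=O)NO)ccc1Cl`) has not yet been measured. Its difference from compound 2 is hydroxycarbamoyl in place of (hydroxycarbamoyl)methyl on a saturated chain carbon, seven bonds along the chain from a carbonyl carbon, with hydroxycarbamoyl in place of (hydroxycarbamoyl)methyl on a saturated chain carbon, seven bonds along the chain from a carbonyl carbon. Within the data shown here, no measured pair shows a change of this kind, so the expectation is a judgement only. A small move toward a lower number is expected, probably within the scatter, and the expected step is a 1.5-fold lower number from compound 2 to compound 3 (0.18 log units; within the scatter). The estimate for compound 3 is 22000 nM, with an expected range of 9000 nM to 50000 nM.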

Compound 3, half-maximal inhibitory concentration: 11500 nM
Estimate against measurement, compound 3: 1.9-fold (0.28 log units) above; the range from low to high includes it.
By their numbers in this assay, from the lowest: compound 1; then compound 3; then compound 2.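

In this assay, the change from (hydroxycarbamoyl)methyl to hydroxycarbamoyl, on a saturated chain carbon seven bonds along the chain from a carbonyl carbon, gives a 2.9-fold lower number from compound 2 to compound 3 (0.46 log units; beyond the scatter). Among these compounds, this is the first single-place comparison, and it shows that the length of the chain carrying the hydroxycarbamoyl end can move the number beyond the scatter, with the shorter chain of this pair giving the stronger inhibition. Nothing at hand accounts for the step.

Among the compounds shown here, with only two chain lengths, one step cannot show whether the number keeps falling as the chain shortens further or passes through an optimum. Also open, going by these compounds, is whether a still shorter chain, or a carboxylic acid in place of the hydroxycarbamoyl end, would keep this inhibition.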